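Triazole-linked iminocyclitols: inhibition of alpha-galactosidase

The source may report more compounds than this note shows. Statements on the series, on what has been measured and on what is new or still open speak of the compounds shown alone.

Measured compounds:
Compound 1 `O[C@@H]1[C@H](O)CN[C@@H]1Cn1cc(-c2ccccc2)nn1`, in an assay on isolated protein for inhibition of alpha-galactosidase (Coffea arabica), with stated times of 5 min and 20 min, tested at 1 mM (on this read-out lower numbers stand for less inhibition and higher numbers for more inhibition at the one concentration tested (going by the name of the read-out)), compound 1 gives <= 50%, which is a limit of the assay.
Compound 2 `O[C@H]1[C@@H](O)CN[C@@H]1Cn1cc(-c2ccccc2)nn1`, in this assay compound 2 is reported as "not active" (no number reported).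
Compound 3 `C[Si](C)(C)Cc1cn(C[C@@H]2NC[C@@H](O)[C@H]2O)nn1`, in this assay compound 3 gives < 50%, which is a limit of the assay.

Compound 3 stands at a limit, as does compound 1 (the limit of <= 50% in this assay, at which 1 of the 3 values shown sits), and compound 2 carries no number at all; none of the three shows inhibition expressed as a measured figure. Compounds 1 and 2 give the same picture, and the fact that compounds 1 and 2 differ only in the configuration as drawn is the only difference between them.

Compound 4 `O[C@@H]1[C@H](O)CN[C@H]1Cn1cc(-c2ccccc2)nn1` is not yet measured. It differs from compound 3 by a group of 6 heavy atoms (6 carbon; one six-membered aromatic ring of carbon only) in place of a group of 5 heavy atoms (4 carbon, 1 silicon; no ring), on an aromatic carbon. Among the compounds with values here, no step between two measured compounds is known for this change, and every value so far sits at or under a limit (the limit of < 50% in this assay, at which 1 of the 3 values shown sits), so in this assay no step beyond the scatter is expected, in either direction. For compound 4 the expected value in this assay is 20%, within 0% to 50%, most likely again reported only as a limit. The expected step that the limit leaves unreadable from compound 3 to compound 4 is estimated as essentially none.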

Compound 4, a percentage reported as inhibition, at one concentration (the size of the read-out at that concentration, not a potency): < 50%
Compound 4: a limit, no number; the forecaster's own chance of this, stated with the estimate: 70%; the middle value lies beyond the limit too.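

In this assay compound 4 gives < 50%, which is a limit of the assay. The steps to compound 4 from compound 3 and from compound 1 cannot be read. The compounds shown leave open whether the phenyl group or the configuration as drawn changes inhibition at all.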